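Camphor hydrazones: tolerance in canine kidney cells

The compounds below may be only part of what the source reports. "The series", "measured", "known", "first", "only" and "open" are said of these compounds alone.

Measured so far:
compound 1 `CC1(C)[C@@H]2CC[C@@]1(C)/C(=N/NC(=O)c1ccccc1)C2`: > 1040000 nM
compound 2 `CC12C=CC3(O1)C(C(=O)N1CCSC13)C2C(=O)N/N=C1\C[C@H]2CC[C@]1(C)C2(C)C`: "not determined" (no result reported)
compound 3 `CC12C=CC3(O1)C(C(=O)N1CCCOC13)C2C(=O)N/N=C1\C[C@H]2CC[C@]1(C)C2(C)C`: > 721000 nM

In an ADME assay on MDCK cells (Canis lupus familiaris) for cytotoxicity, read by MTT assay, with a stated time of 48 h (a higher number here means that more compound is tolerated, a lower number that less compound is tolerated), compound 1 gives > 1040000 nM, which is a limit of the assay and not a number. Compound 3 gives > 721000 nM in this assay, likewise a limit. Compound 2 has no result in this assay. Compound 1 therefore stands at one of two limits, and no compound shown has a single number.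

Compound 4 `CC1(C)[C@@H]2CC[C@@]1(C)/C(=N/NC(=O)c1cccs1)C2` differs from compound 1 by thiophen-2-yl in place of phenyl on a carbonyl carbon. Within the data shown here, no step between measured compounds is available to size this change. In this assay the step of an at least 1.0-fold lower number from compound 1 to compound 4 (0.01 log units; that floor lies within the scatter) is expected to stay within the scatter, with no direction preferred. Compound 4 is expected to give 1000000 nM, in the range 500000 nM to 2000000 nM, most probably reported again only as a limit.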

Compound 4, half-maximal cytotoxic concentration: 1030000 nM
The estimate for compound 4 lay 1.0-fold (0.01 log units) below the measured number; measured number inside the range.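

Thiophen-2-yl in place of phenyl on a carbonyl carbon gives the only single number so far in this assay: compound 4 gives 1030000 nM. Compound 1 gives > 1040000 nM, which is a limit of the assay and not a number. The step is therefore a number no higher from compound 1 to compound 4 (the limit leaves the size open) and its size cannot be read, because the comparison rests on that limit: the limit of > 1040000 nM in this assay, at which 1 of the 4 values shown sits.

Still open, on these data alone, is the actual value of compound 1. Also open, as far as these compounds go, is what an amine or a carboxylic acid on this carbonyl carbon would give in this assay.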